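This account rests on a few compounds, and the source may have more. Where it says the series, first, only, none or still open, it means among the compounds named here.

Working notes on the series. One core is shared by compound 1 `O=c1[nH]c2ncn(Cc3ccncc3)c2c(=O)n1O`, compound 3 `O=c1[nH]c2ncn(C3CCCCC3)c2c(=O)n1O`, compound 2 `C=CCOn1c(=O)[nH]c2ncn(Cc3ccccc3)c2c1=O` and the not yet measured compound 4 `O=c1[nH]c2ncn(Cc3ccccc3)c2c(=O)n1O`. Read in an assay on isolated protein for inhibition of CCR4-NOT transcription complex subunit 7 (Homo sapiens), read by fluorescence (a lower number here means a stronger inhibitor, a higher number a weaker inhibitor), compound 1 gives 23300 nM and compound 3 gives 28200 nM; both carry a free hydroxy on the oxygen on the aromatic ring, and the two values lie within the usual scatter of each other. For compound 2 only a limit is known: in this assay compound 2 gives > 1000000 nM, which is a limit of the assay and not a number. Compound 2 thus stands at the weak edge of what has been measured, as the limit of > 1000000 nM in this assay, at which 1 of the 3 values shown sits, shows. The change from compound 2 to compound 4 is hydrogen in place of allyl on an oxygen on an aromatic ring, so compound 4 carries the free hydroxy of compound 1 and compound 3 while keeping the benzyl of compound 2. Among the compounds with values here, no such step has been measured. Compound 1 gives 23300 nM and compound 3 gives 28200 nM with that free hydroxy in place, which sets the expectation. The expected step is a large fall in the number, well beyond the scatter, of about an at least 40-fold lower number from compound 2 to compound 4 (1.60 log units; beyond the scatter). Compound 4 is expected to come out near 25000 nM, with a range of 8000 nM to 80000 nM in this assay.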

Compound 4, half-maximal inhibitory concentration: 10400 nM
Compound 4: the middle estimate sits 2.4-fold (0.38 log units) above what was measured; the range from low to high includes it.
By their numbers in this assay, from the lowest: compound 4; then compounds 1 and 3 (each within the scatter of the next). At a limit, above all of these: compound 2.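

With the benzyl held fixed, allyloxy to hydroxy on the shared core gives an at least 96-fold lower number from compound 2 to compound 4 (1.98 log units; beyond the scatter) in this assay, so a capped and a free oxygen at this position are now compared directly, with no second change in the pair. Compound 2 is a limit and not a number, and the step is therefore a bound only: the limit of > 1000000 nM in this assay, at which 1 of the 4 values shown sits. Phenyl in place of pyridin-4-yl on a saturated chain carbon bound to an aromatic nitrogen gives a 2.2-fold lower number from compound 1 to compound 4 (0.35 log units; beyond the scatter), a modest step that is small beside the change on the oxygen, so within these compounds the number moves far more with the oxygen substituent than with this swap of ring.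

Whether the loss seen with allyl extends to every group on this oxygen stays open, as a smaller group such as methyl or a carbonyl group such as acetyl has no counterpart among the compounds shown. Also open, going by these compounds, is how the number responds to a carboxylic acid or an amine on the phenyl ring of compound 4, or to a longer chain in place of its benzyl.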